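Compound 4: Trading a Fluorophenyl for a Chlorophenyl

The source may report more compounds than this note shows. Statements on the series, on what has been measured and on what is new or still open speak of the compounds shown alone.

Three members of this series have been measured in a functional assay on DU-145 cells (Homo sapiens) for inhibition, read by trypan blue exclusion, with a stated time of 96 h; a higher number here means a weaker inhibitor of growth, a lower number a stronger inhibitor of growth. Compound 1 `O=C(/C(=C\c1ccc(O)cc1)S(=O)(=O)Cc1ccc(Cl)c(Cl)c1)c1ccc(Cl)cc1` gives 10000 nM in this assay. Compound 2 `O=C(/C(=C\c1ccccc1F)S(=O)(=O)c1ccc(Br)cc1)c1ccc(Cl)cc1` gives 25000 nM in this assay, and compound 3 `Cc1ccc(S(=O)(=O)/C(=C/c2ccccc2F)C(=O)c2ccc(Cl)cc2)cc1` gives 2500 nM in this assay. Compound 3 therefore stands lowest of the three numbers; compound 1 is its nearest neighbour and compound 2 its furthest, and both gaps lie beyond the scatter. Among the compounds with values here, the only one-place step among the measured compounds is a 10-fold lower number from compound 2 to compound 3 (1.00 log units; beyond the scatter), which concerns the sulfone-bearing ring, not the ring on the chain.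

Compound 4 `Cc1ccc(S(=O)(=O)/C(=C/c2ccc(Cl)cc2)C(=O)c2ccc(Cl)cc2)cc1` differs from compound 3 as follows: 4-chlorophenyl in place of 2-fluorophenyl on a double-bonded chain carbon bound to a double-bonded chain carbon. Within the data shown here, no measured step touches this change. Compound 1 carries a different ring on the same chain carbon, but it also carries a different sulfone group, so its value next to that of compound 3 cannot be read as a single effect. With nothing that bears directly on the change, the most reasonable expectation is a step of no more than the scatter, in no particular direction, so that no change at the digits printed from compound 3 to compound 4 (within the scatter) is the estimated step. Compound 4 is accordingly expected to give about 2500 nM in this assay, with a range from 800 nM to 8000 nM.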

Compound 4, concentration for 50% growth inhibition: 1000 nM
For compound 4 the middle estimate is 2.5-fold (0.40 log units) above the measured one; the range from low to high includes it.
By their numbers in this assay, from the lowest: compound 4; then compound 3; then compound 1; then compound 2.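

In this assay, putting 4-chlorophenyl in place of 2-fluorophenyl on a double-bonded chain carbon bound to a double-bonded chain carbon gives a 2.5-fold lower number from compound 3 to compound 4 (0.40 log units; beyond the scatter), the first one-place step read at this position. The number here therefore responds to the ring on the chain, while the earlier step, a 10-fold lower number from compound 2 to compound 3 (1.00 log units; beyond the scatter), concerned only the sulfone-bearing ring, so a change on either ring has now been seen to move the number beyond the scatter in this series. Nothing in the information at hand bears on why the number falls with this exchange.

The exchange alters both the halogen and its place on the ring, so this one step cannot say which of the two matters, and a 4-fluorophenyl or a 2-chlorophenyl at the same chain carbon would be needed to separate them. From the compounds shown here alone, it also remains open how a ring carrying an amine or a carboxylic acid would fare at this position, and whether bromo in place of methyl on the sulfone-bearing ring would raise the number as much with 4-chlorophenyl on the chain.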